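A Methyl for Fluoro Swap on a Weak Growth Inhibitor

A few compounds are considered here, and "the series" means these few. Any claim that something is new, unique, unknown or untested is made for them only; others in the source may bear on it.

Compound 1 `Cc1ccc(/C=C(\C(=O)c2ccc(Cl)cc2)S(=O)(=O)Cc2ccc(F)cc2)s1` is the weaker of two compounds measured in a functional assay on DU-145 cells (Homo sapiens) for inhibition, read by trypan blue exclusion, with a stated time of 96 h; a lower number here means a stronger inhibitor of growth, a higher number a weaker inhibitor of growth: compound 1 gives 50000 nM, while compound 2 `Cc1ccc(/C=C(\C(=O)c2ccc(Br)cc2)S(=O)(=O)Cc2ccc(F)cc2)s1` gives 1000 nM. Going by the values given here, the only change between those two is a 50-fold lower number from compound 1 to compound 2 (1.70 log units; beyond the scatter), a shift that takes place on the aryl ketone side of the shared core. Compound 3 `Cc1ccc(CS(=O)(=O)/C(=C/c2ccc(C)s2)C(=O)c2ccc(Cl)cc2)cc1` has not yet been measured. It differs from compound 1 elsewhere, on the benzyl ring attached to the sulfonyl group: methyl in place of fluoro on an aromatic carbon.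

Among the compounds with values here, no measured step touches this benzyl ring, so the single recorded step from compound 1 to compound 2 does not speak to the change from compound 1 to compound 3. The only footing is the weak starting point of compound 1 itself. With nothing in the data to point up or down, the most defensible expectation is that compound 3 stays near compound 1 within the usual scatter, so the step is estimated as a 1.3-fold lower number from compound 1 to compound 3 (0.10 log units; within the scatter). Compound 3 is accordingly expected to give about 40000 nM in this assay, with a plausible range from 8000 nM to 100000 nM.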

Compound 3, concentration for 50% growth inhibition: 25000 nM
Beside the measured number, compound 3's estimate is 1.6-fold (0.20 log units) above it, and the stated range covers the measured number.
By their numbers in this assay, from the lowest: compound 2; then compounds 3 and 1 (each within the scatter of the next).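

Going by these compounds alone, this is the first measured change on the benzyl ring, and in this assay the step from fluoro to methyl, on the aromatic carbon para to a large group, gives a 2.0-fold lower number from compound 1 to compound 3 (0.30 log units; within the scatter). So these two small groups cannot be told apart at this position, and compound 3, like compound 1, remains in the same weak range, while the bromo for chloro change on the other side of the shared core gives a 50-fold lower number from compound 1 to compound 2 (1.70 log units; beyond the scatter), a step beyond the scatter. Nothing in the available evidence explains either result, so the data show how much the numbers move but not the reason.

The compounds shown leave open whether this position responds at all to groups that differ more from fluoro and methyl, such as an amine, a carboxylic acid or a longer chain. They also leave open whether the same fluoro to methyl change would read the same way on the bromo compound 2, whose number sits in a different range from that of compound 1.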